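A nitrile swap on the ether side of compound 2

A few compounds are considered here, and "the series" means these few. Any claim that something is new, unique, unknown or untested is made for them only; others in the source may bear on it.

In a functional assay on LNCaP cells (Homo sapiens) for antiproliferative activity, read by propidium iodide staining, with a stated time of 96 h (on this read-out higher numbers stand for weaker inhibition and lower numbers for stronger inhibition), compound 1 `CC(O)(COc1ccc(S(F)(F)(F)(F)F)cc1)C(=O)Nc1cccc(S(F)(F)(F)(F)F)c1` gives 8000 nM, while compound 2 `CC(O)(COc1cccc(C(F)(F)F)c1)C(=O)Nc1cccc(S(F)(F)(F)(F)F)c1` gives 28800 nM. Compound 2 therefore has the higher of the two numbers, which means the weaker inhibition, and the gap between them lies beyond the scatter.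

Compound 3 `CC(O)(COc1ccc(C#N)cc1)C(=O)Nc1cccc(S(F)(F)(F)(F)F)c1` differs from compound 2 in one place: 4-cyanophenyl in place of 3-(trifluoromethyl)phenyl on an oxygen on a saturated carbon. In words, this is 4-cyanophenyl in place of 3-(trifluoromethyl)phenyl on an oxygen on a saturated carbon.

Within the data shown here, no measured pair shows this exact change, so any forecast is loose. Compound 1 at 8000 nM shows only that a lower number than that of compound 2 occurs among these relatives. A modest move toward a lower number in this assay is expected, though it may not clear the scatter. The estimated step is a 2.1-fold lower number from compound 2 to compound 3 (0.31 log units; beyond the scatter). For compound 3 the estimated value is 14000 nM, with an expected range from 4000 nM to 40000 nM.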

Compound 3, half-maximal inhibitory concentration: 30000 nM
Compound 3: the middle estimate sits 2.1-fold (0.33 log units) below what was measured, and the stated range covers the measured number.
By their numbers in this assay, from the lowest: compound 1; then compounds 2 and 3 (each within the scatter of the next).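

Swapping the ether-side ring gives a 1.0-fold higher number from compound 2 to compound 3 (0.02 log units; within the scatter) in this assay, so at this position on an oxygen on a saturated carbon, 4-cyanophenyl and 3-(trifluoromethyl)phenyl cannot be told apart, even though only the former carries a hydrogen-bond acceptor. The nitrile in place of pentafluorosulfanyl on an aromatic carbon gives a 3.8-fold higher number from compound 1 to compound 3 (0.57 log units; beyond the scatter), a change beyond the scatter toward weaker inhibition, so the group on this ring can matter. No measurement shown here explains either result.

Going by these compounds, compounds 2 and 3 differ in both the group and where it sits on the ring, so the effect of each alone remains open; 3-cyanophenyl or 4-(trifluoromethyl)phenyl would separate them. Also open, on these data alone, is how this position would respond to an amine or a carboxylic acid on the ring.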